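One Ring Swap Repeated on a Second Quinoline Core

The compounds below may be only part of what the source reports. "The series", "measured", "known", "first", "only" and "open" are said of these compounds alone.

Compound 1 `O=C(NC1CCCCC1)NS(=O)(=O)N1CCC(CCNC(=O)c2ccc3ccccc3n2)CC1` gives 11% in a functional assay on the whole organism (blood) with Rattus norvegicus as the target, with stated times of 24 h and 1 h, at a dose of 5 mg/kg by the intraperitoneal route; on this read-out higher numbers stand for a stronger effect at the one dose given and lower numbers for a weaker effect. Compound 2 `O=C(NC[C@@H]1C[C@@H]2C=C[C@@H]1C2)NS(=O)(=O)N1CCC(CCNC(=O)c2ccc3ccccc3n2)CC1` carries a group of 8 heavy atoms (8 carbon; 2 five-membered non-aromatic rings of carbon only) in place of a group of 6 heavy atoms (6 carbon; one six-membered non-aromatic ring of carbon only), on an amide-type nitrogen and in this assay compound 2 gives 21%, a change of a number 10 percentage points higher from compound 1 to compound 2 (within the scatter). Compound 3 `O=C(NC1CCCCC1)NS(=O)(=O)N1CCC(CCNC(=O)c2cc(Cl)cc3cccnc23)CC1` differs from compound 1 in its core by 6-chloroquinolin-8-yl in place of quinolin-2-yl on a carbonyl carbon; in this assay compound 3 gives 52%, a step of a number 41 percentage points higher from compound 1 to compound 3 (beyond the scatter). Going by the values given here, compound 4 `O=C(NC[C@@H]1C[C@@H]2C=C[C@@H]1C2)NS(=O)(=O)N1CCC(CCNC(=O)c2cc(Cl)cc3cccnc23)CC1` has not been measured; it carries a group of 8 heavy atoms (8 carbon; 2 five-membered non-aromatic rings of carbon only) in place of a group of 6 heavy atoms (6 carbon; one six-membered non-aromatic ring of carbon only), on an amide-type nitrogen, which is the same change as the one made from compound 1 to compound 2, at the same place. Because that earlier change moved the read-out by only a number 10 percentage points higher from compound 1 to compound 2 (within the scatter), a similarly small step is expected from compound 3 to compound 4, namely a number 6 percentage points higher from compound 3 to compound 4 (within the scatter). Compound 4 is therefore estimated at 58%, with a likely range from 40% to 76% in this assay.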

Compound 4, a percentage reported as activity, at one dose (the size of the read-out at that dose, not a potency): 35%
Estimate against measurement, compound 4: 23 percentage points above; measured number below the stated range.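

In this assay, replacing cyclohexyl with the group of two five-membered rings gives a number 17 percentage points lower from compound 3 to compound 4 (beyond the scatter), so the effect of this swap depends on the core that carries it: the same change on two cores in this assay, a number 10 percentage points higher (within the scatter) from compound 1 to compound 2 and a number 17 percentage points lower (beyond the scatter) from compound 3 to compound 4, 27 percentage points apart, beyond the scatter of two such steps

Seen from the other side, changing the core gives a number 14 percentage points higher from compound 2 to compound 4 (beyond the scatter), which keeps its direction but not its size: the same change on two cores in this assay, a number 41 percentage points higher (beyond the scatter) from compound 1 to compound 3 and a number 14 percentage points higher (beyond the scatter) from compound 2 to compound 4, 27 percentage points apart, beyond the scatter of two such steps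

These four compounds show that the two changes do not act independently, but they do not show why, and two cores give no rule for a third.

Still open, going by these compounds, is whether a phenyl or cyclopentyl group on the amide-type nitrogen would depend on the core in the same way. On these data alone, it is also open whether a fluoro group in place of the chloro group would change this dependence.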